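From trifluoromethyl to methoxy: an estimate for compound 4

The source may report more compounds than this note shows. Statements on the series, on what has been measured and on what is new or still open speak of the compounds shown alone.

Compound 1 `COc1ccc(Nc2ccc3c(c2)S(=O)(=O)C=C3)cc1`: 1210 nM
Compound 2 `O=S1(=O)C=Cc2cccc(Nc3ccc(C(F)(F)F)cc3)c21`: 1820 nM
Compound 3 `Cc1cc(C)cc(Nc2cccc3c2S(=O)(=O)C=C3)c1`: 8800 nM

These values come from a functional assay on MCF7 cells (Homo sapiens) for antiproliferative activity, read by MTT assay, with a stated time of 72 h; on this read-out lower numbers stand for stronger inhibition and higher numbers for weaker inhibition. Compound 2 stands level with compound 1, within the scatter, and at a clearly lower number than compound 3. Compound 4 `COc1ccc(Nc2cccc3c2S(=O)(=O)C=C3)cc1` differs from compound 2 by methoxy in place of trifluoromethyl on an aromatic carbon. Within the data shown here, no measured pair shows this change alone, so the evidence is indirect. Compound 1 also carries methoxy and gives 1210 nM, so a number near that of compound 2 seems likely. The expected step of a 1.2-fold lower number from compound 2 to compound 4 (0.08 log units; within the scatter) stays within the scatter. For compound 4 the estimated value is 1500 nM, with an expected range of 500 nM to 5000 nM.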

Compound 4, half-maximal inhibitory concentration: 940 nM
Compound 4: middle estimate off by 1.6-fold (0.20 log units), on the high side; the range from low to high includes it.
By their numbers in this assay, from the lowest: compounds 4, 1 and 2 (each within the scatter of the next); then compound 3.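

The step of a 1.9-fold lower number from compound 2 to compound 4 (0.29 log units; within the scatter) in this assay gives the first direct view of this change, on an aromatic carbon para to a large group. Here methoxy and trifluoromethyl read alike, although methoxy brings a hydrogen-bond acceptor and trifluoromethyl brings none. Nothing measured here explains this likeness.

As far as these compounds go, whether other groups would also read alike at this carbon stays open: an amine, a carboxylic acid or a longer chain could give a very different number. A single pair also cannot show whether this change behaves the same way elsewhere on the core.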